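The source may hold more compounds than are shown below. What is called first, only, known or untested is meant among the compounds shown, and "the series" means these compounds.

Compound 1 `COc1ncc(-c2ccc3ncc(NCc4ccccc4)c(OC)c3c2)cc1NS(=O)(=O)c1ccc(F)cc1F` carries a benzyl group on the ring nitrogen of the shared core, and compound 2 `COc1ccc(CNc2cnc3ccc(-c4cnc(OC)c(NS(=O)(=O)c5ccc(F)cc5F)c4)cc3c2OC)cc1` differs from it only by a methoxy in place of hydrogen on an aromatic carbon of that benzyl group. In a functional assay on HCT-116 cells (Homo sapiens) for antiproliferative activity, read by sulforhodamine B assay, with a stated time of 72 h (a higher number here means a weaker inhibitor, a lower number a stronger inhibitor), compound 1 gives 16800 nM, while compound 2 gives 10200 nM. The step of a 1.6-fold lower number from compound 1 to compound 2 (0.22 log units; within the scatter) is small, so the two compounds stand together at the weaker end of potency, and compound 2 has the lower of the two numbers shown without being separated from compound 1 beyond the scatter.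

Compound 3 `COc1ncc(-c2ccc3ncc(NC(=O)CN4CCCC(O)C4)c(OC)c3c2)cc1NS(=O)(=O)c1ccc(F)cc1F` is the unmeasured compound. Its change from compound 2 is ((3-hydroxypiperidin-1-yl)methyl)carbonyl in place of 4-methoxybenzyl on a nitrogen on an aromatic ring. Within the data shown here, only the step from compound 1 to compound 2 is available, and it concerns a far smaller change of the same group, so it gives little guidance. The expected step of a 1.2-fold higher number from compound 2 to compound 3 (0.07 log units; within the scatter) therefore remains uncertain in direction, and compound 3 is estimated at 12000 nM with a range from 3000 nM to 50000 nM.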

Compound 3, half-maximal inhibitory concentration: 1770 nM
Compound 3: the middle estimate sits 6.8-fold (0.83 log units) above what was measured, and the stated range ends above it.
By their numbers in this assay, from the lowest: compound 3; then compounds 2 and 1 (each within the scatter of the next).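

In this assay, this nitrogen tolerates more than small edits to the benzyl group: replacing 4-methoxybenzyl with ((3-hydroxypiperidin-1-yl)methyl)carbonyl gives a 5.8-fold lower number from compound 2 to compound 3 (0.76 log units; beyond the scatter), and replacing benzyl with the same group gives a 9.5-fold lower number from compound 1 to compound 3 (0.98 log units; beyond the scatter). Both steps lie beyond the scatter, whereas adding a methoxy to the benzyl group did not move the number beyond it, so exchanging the whole group reveals a response that the earlier pair could not show. Nothing shown here gives a measured reason for this drop.

The carbonyl, the non-aromatic ring and the hydroxyl all enter together, so the compounds shown do not say which of them goes with the lower number. As far as these compounds go, whether a plain acetyl group, or a piperidine without its hydroxyl, would give a similar number remains open.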